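Swapping the nitrotolyl ketone arm for a fluorophenyl arm

The source may report more compounds than this note shows. Statements on the series, on what has been measured and on what is new or still open speak of the compounds shown alone.

This account concerns a series of aryl isoxazole amides tested in an ADME assay on Vero cells (Chlorocebus sabaeus) for cytotoxicity, read by MTT assay, with a stated time of 72 h; on this read-out lower numbers stand for higher toxicity in this test and higher numbers for lower toxicity in this test. Compound 1 `COC(=O)c1cc(-c2cccc(NC(=O)c3ccc(/C=C/C(=O)c4cccc([N+](=O)[O-])c4)cc3)c2)on1` carries a nitrophenyl ketone at the end of the chalcone-like chain, and in this assay compound 1 reaches only the limit > 40 ug/mL. Compound 2 `COC(=O)c1cc(-c2cccc(NC(=O)c3ccc(/C=C/C(=O)c4ccc(C)c([N+](=O)[O-])c4)cc3)c2)on1` differs by a methyl in place of hydrogen on an aromatic carbon, and in this assay compound 2 likewise stands at a limit, > 80 ug/mL. The step that the two limits leave unreadable from compound 1 to compound 2 therefore cannot be read; both the limit of > 40 ug/mL in this assay, at which 1 of the 3 values shown sits, and the limit of > 80 ug/mL in this assay, at which 1 of the 3 values shown sits, are limits, not numbers. Compound 3 `CCOC(=O)c1cc(-c2cccc(NC(=O)c3cccc(C(F)(F)F)c3)c2)on1` has no result in this assay, "not determined" (no result reported). Compound 2 thus sits at the higher of the two limits seen, with no numbered value anywhere in the set.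

Compound 4 `COC(=O)c1cc(-c2cccc(NC(=O)c3ccc(/C=C/C(=O)c4ccc(F)cc4)cc3)c2)on1` differs from compound 2 as follows: 4-fluorophenyl in place of 4-methyl-3-nitrophenyl on a carbonyl carbon. Within the data shown here, no measured step bears on this change, since the single step available is unreadable. With every measured compound at a limit, compound 4 is expected to stay at or near the same region, and the step of a number no higher from compound 2 to compound 4 (the limit leaves the size open) is expected to lie within the scatter. Compound 4 is therefore estimated at 80 ug/mL, with a range from 40 ug/mL to 160 ug/mL, and a limit rather than a number is the more likely outcome.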

Compound 4, half-maximal cytotoxic concentration: > 20 ug/mL
Compound 4: a limit, no number; the forecaster's own chance of this, stated with the estimate: 70%; the middle value does not contradict the limit.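

Compound 4 also gives only a limit, so the steps linking it to compound 1 and compound 2 in this assay cannot be read: the limit of > 20 ug/mL in this assay, at which 1 of the 4 values shown sits. The compounds shown leave open whether 4-fluorophenyl in place of 4-methyl-3-nitrophenyl changes cytotoxicity at all, and in which direction.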